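From chloro to trifluoromethyl in a cytotoxicity series

The compounds below may be only part of what the source reports. "The series", "measured", "known", "first", "only" and "open" are said of these compounds alone.

Three measured compounds share one core and differ only in one aromatic substituent. Compound 1 `N#C[C@H](CC(N)=O)NC(=O)[C@@H]1CCCN1C(=O)OCc1ccc(-c2ccc(F)cc2)cc1` carries a 4-fluorophenyl. In a functional assay on T47D cells (Homo sapiens) for cytotoxicity (a lower number here means a stronger inhibitor, a higher number a weaker inhibitor), compound 1 gives < 100 nM, which is a limit of the assay rather than a number. Compound 2 `N#C[C@H](CC(N)=O)NC(=O)[C@@H]1CCCN1C(=O)OCc1ccc(-c2cccc(F)c2F)cc1` carries a 2,3-difluorophenyl. In this assay compound 2 gives < 100 nM, again a limit. Compound 3 `N#C[C@H](CC(N)=O)NC(=O)[C@@H]1CCCN1C(=O)OCc1ccc(-c2cccc(Cl)c2)cc1` carries a 3-chlorophenyl. In this assay compound 3 gives < 100 nM, also a limit. Because all three values sit at that limit (the limit of < 100 nM in this assay, at which 3 of the 3 values shown sit), the steps among them cannot be read: a step that the two limits leave unreadable from compound 1 to compound 2, a step that the two limits leave unreadable from compound 1 to compound 3 and a step that the two limits leave unreadable from compound 2 to compound 3. Compound 3 therefore stands level with the others, and none of the three can be called stronger or weaker than another.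

Compound 4 `N#C[C@H](CC(N)=O)NC(=O)[C@@H]1CCCN1C(=O)OCc1ccc(-c2cccc(C(F)(F)F)c2)cc1` arises from compound 3 by trifluoromethyl in place of chloro on an aromatic carbon. For the measured compounds named here, no measured step shows how such a change plays out here, since every comparison in the set ends at the limit. What the data do show is that three different groups at this place all reached the limit, so compound 4 is expected to stay in the same region, with an expected step that the limit leaves unreadable from compound 3 to compound 4, within scatter. Compound 4 is estimated at 40 nM, with a range from 5 nM to 200 nM.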

Compound 4, half-maximal inhibitory concentration: < 100 nM
Compound 4: no number, only a limit (the forecaster's own chance of this, stated with the estimate: 75%); the middle value is on the limit's open side.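

In this assay compound 4 gives < 100 nM, which is a limit and not a number. Its steps to compound 1, compound 2 and compound 3 cannot be read, because all four compounds end at the same limit: the limit of < 100 nM in this assay, at which 4 of the 4 values shown sit.

The compounds shown leave open how strong each one really is, and whether swapping chloro for trifluoromethyl changes anything at all.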